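From a Fluorophenyl to a Chlorophenyl on the Ring Nitrogen

This account rests on a few compounds, and the source may have more. Where it says the series, first, only, none or still open, it means among the compounds named here.

Measured so far:
Compound 1, `Cc1c(C#N)c(-c2ccccc2)nn1CCCN1CCN(c2ccc(F)cc2)CC1`: 9%
Compound 2, `CC(=O)c1cccn1CCCN1CCN(c2ccc(F)cc2)CC1`: 0%

In a functional assay on the whole organism (Abdomen, strain Swiss) for inhibition, with Mus musculus as the target, with stated times of 30 min, 10 min and 5 min, at a dose of 10 mg/kg by the oral route (on this read-out higher numbers stand for a stronger effect at the one dose given and lower numbers for a weaker effect), compound 1 gives 9% and compound 2 gives 0%. Compound 2 has the lower of the two numbers, yet the gap to compound 1 lies within the usual scatter of this kind of measurement, so the two compounds cannot be told apart: both sit close to the bottom of the scale.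

Compound 3, `CC(=O)c1cccn1CCCN1CCN(c2cccc(Cl)c2)CC1`, is not yet measured. It differs from compound 2 in a single place: 3-chlorophenyl in place of 4-fluorophenyl on an amine nitrogen in a ring

Within the data shown here, no pair of measured compounds shows what this swap does, so there is nothing in the numbers so far that points one way or the other. Among the measured compounds shown here, with both measured compounds near zero and no measured step to lean on, the step from compound 2 to compound 3 is expected to be small, a number 5 percentage points higher from compound 2 to compound 3 (within the scatter), not beyond the scatter in either direction. Compound 3 is therefore expected to give about 5%, with a likely range from 0% to 25%.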

Compound 3, a percentage reported as inhibition, in the whole organism at one dose (the size of the read-out at that dose, not a potency): 3%
For compound 3 the middle estimate is 2 percentage points above the measured one; the measured number falls inside the stated range.
By their numbers in this assay, from the lowest: compounds 2, 3 and 1 (each within the scatter of the next).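

Among these compounds, the first readable step at this position comes with 3-chlorophenyl in place of 4-fluorophenyl on the amine nitrogen in the ring: in this assay it is a number 3 percentage points higher from compound 2 to compound 3 (within the scatter) and so the two compounds cannot be told apart. Among the compounds shown here, until now the only group seen at this place was 4-fluorophenyl, so this pair is the first sign that a different halogen-bearing phenyl ring can sit here with no readable difference at this one dose, though both compounds stay near the bottom of the scale. Nothing at hand explains the result.

Because neither compound gives much of an effect, the pair cannot say whether this position matters at all, since a swap has little room to show up so close to the bottom of the scale. Still open, as far as these compounds go, is whether another group on the same nitrogen, such as 2-methoxyphenyl, a plain phenyl or a benzyl, would lift the number clear of the scatter.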